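The source may hold more compounds than are shown below. What is called first, only, known or untested is meant among the compounds shown, and "the series" means these compounds.

Compound 1 `Cc1cc(O)cc(-c2nn(CC#N)cc2-c2ccnc(-c3ccc(Oc4ccccc4)cc3)c2)c1` and compound 2 `COc1cc(C)cc(-c2nn(CC#N)cc2-c2ccnc(-c3ccc(N(C)C)cc3)c2)c1` share one core and differ from each other in two places at once. In a functional assay on SK-MEL-28 cells (Homo sapiens) for cytotoxicity, read by sulforhodamine B assay, with a stated time of 48 h, tested at 100 nM (on this read-out lower numbers stand for a stronger effect and higher numbers for a weaker effect at the one concentration tested), compound 1 gives 95% and compound 2 gives 44%; compound 2 stands lowest of the two numbers, beyond the scatter from compound 1. Compound 3 `Cc1cc(O)cc(-c2nn(CC#N)cc2-c2ccnc(-c3ccc(N(C)C)cc3)c2)c1` follows compound 2 with a single change, methoxy to hydroxy: hydrogen in place of methyl on an oxygen on an aromatic ring. Going by the values given here, no measured pair isolates this change, so its direction cannot be read from the two numbers. A small step, or none beyond the scatter, is expected: a number 8 percentage points higher from compound 2 to compound 3 (within the scatter). Compound 3 is estimated at 52%, within 25% to 82%.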

Compound 3, a percentage reported as activity, at one concentration (the size of the read-out at that concentration, not a potency): 96%
Estimate against measurement, compound 3: 44 percentage points below; measured number outside the range, above it.
By their numbers in this assay, from the lowest: compound 2; then compounds 1 and 3 (each within the scatter of the next).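

In this assay the oxygen on the aromatic ring proves a sensitive place: hydrogen in place of methyl gives a number 52 percentage points higher from compound 2 to compound 3 (beyond the scatter) in a single change. With hydroxy in place, dimethylamino in place of phenoxy gives a number 1 percentage points higher from compound 1 to compound 3 (within the scatter), so this pair shows no step beyond the scatter on that aromatic carbon. No measured evidence explains either result.

As far as these compounds go, whether the methoxy-to-hydroxy step also holds with phenoxy remains open. So does the outcome with ethoxy or a longer alkoxy chain on that oxygen.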